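The compounds below may be only part of what the source reports. "The series", "measured", "known", "first", "only" and "open" are said of these compounds alone.

Compound 1 `COc1ccc(-n2nncc2CN2C(=O)C3(C(C#N)=C(N)Oc4c3c3nc5ccccc5nc3c3ccccc43)c3ccccc32)cc1` gives > 50000 nM, a limit of the assay and not a number.
Compound 2 `Cc1cc(C)cc(-n2nncc2CN2C(=O)C3(C(C#N)=C(N)Oc4c3c3nc5ccccc5nc3c3ccccc43)c3ccccc32)c1` gives > 50000 nM, likewise a limit.
Compound 3 `COc1ccc(-n2nncc2CN2C(=O)C3(C(C#N)=C(N)Oc4c(N)cc5nc6ccccc6nc5c43)c3ccccc32)cc1` gives > 50000 nM, likewise a limit.

In a functional assay on A549 cells (Homo sapiens) for antiproliferative activity, read by MTT assay, with a stated time of 48 h (on this read-out higher numbers stand for weaker inhibition and lower numbers for stronger inhibition), compound 3 therefore stands at the limit of detection, and so does every other compound measured here, which is why the limit of > 50000 nM in this assay, at which 3 of the 3 values shown sit, is the only firm point of reference. Among the measured compounds shown here, the single step between measured compounds, a step that the two limits leave unreadable from compound 1 to compound 2, runs from one limit to another, so its size cannot be read. Compound 4 `N#CC1=C(N)Oc2c(N)cc3nc4ccccc4nc3c2C12C(=O)N(Cc1cnnn1-c1c(Cl)cc(Cl)cc1Cl)c1ccccc12` is the next compound in line. It differs from compound 3 in one place: 2,4,6-trichlorophenyl in place of 4-methoxyphenyl on an aromatic nitrogen. For the measured compounds named here, no measured step involves a 2,4,6-trichlorophenyl group, and the only earlier change on the same aromatic nitrogen, from compound 1 to compound 2, gave no readable size. Nothing among the values shown points to a gain beyond the scatter; each variation on this aromatic nitrogen so far has left the compound at the limit. Compound 4 is therefore expected to remain there as well, with the step of a number no higher from compound 3 to compound 4 (the limit leaves the size open) expected to be flat within the scatter. The estimate for compound 4 is 50000 nM, in the range 25000 nM to 200000 nM, most likely reported once more only as a limit.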

Compound 4, half-maximal inhibitory concentration: > 50000 nM
Compound 4: no number, only a limit; the forecaster's own chance of this, stated with the estimate: 85%; the middle value sits exactly at the limit.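

In this assay compound 4 gives > 50000 nM, a limit and not a number. Among the compounds shown here, compound 3 also sits at a limit, so no step from compound 3 to compound 4 can be read. The compounds shown leave open whether any of them has a measurable value, and which change to the group on the aromatic nitrogen or to the shared core might produce one.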